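The source may report more compounds than this note shows. Statements on the series, on what has been measured and on what is new or still open speak of the compounds shown alone.

Measured compounds:
compound 1, `CCn1c(C(=O)N[C@@H](C)CO)ccc1C(CC)(CC)c1ccc(OCS(=O)(=O)c2ccccc2)c(C)c1`, in a functional assay on PC-3 cells (Homo sapiens) for antiproliferative activity, read by MTT assay, with a stated time of 24 h; a lower number here means a stronger inhibitor, a higher number a weaker inhibitor: 9520 nM
compound 2, `CCn1c(C(=O)N[C@H](CO)CCO)ccc1C(CC)(CC)c1ccc(OCS(=O)(=O)c2ccccc2)c(C)c1`, in this assay: 12100 nM
compound 3, `CCn1c(C(=O)N[C@H](CO)CCCO)ccc1C(CC)(CC)c1ccc(OCS(=O)(=O)c2ccccc2)c(C)c1`, in this assay: 6810 nM

Compound 3 gives the lowest of the three numbers, yet the steps reaching it, a 1.4-fold lower number from compound 1 to compound 3 (0.15 log units; within the scatter) and a 1.8-fold lower number from compound 2 to compound 3 (0.25 log units; within the scatter), both lie within the scatter, as does a 1.3-fold higher number from compound 1 to compound 2 (0.10 log units; within the scatter), so the three compounds cannot be ranked against each other. Compound 4, `CCn1c(C(=O)N[C@@H](CCC(=O)O)C(=O)O)ccc1C(CC)(CC)c1ccc(OCS(=O)(=O)c2ccccc2)c(C)c1`, differs from compound 3 as follows: a group of 9 heavy atoms (5 carbon, 4 oxygen; no ring) in place of a group of 7 heavy atoms (5 carbon, 2 oxygen; no ring), on an amide-type nitrogen. Among the compounds with values here, none of the measured steps involves this kind of exchange; they only show that several variations of the group on the amide-type nitrogen leave the numbers in this assay within the scatter of one another. On that basis compound 4 is expected to show a modest step, a 1.3-fold higher number from compound 3 to compound 4 (0.12 log units; within the scatter), with a wide uncertainty. The estimate for compound 4 in this assay is 9000 nM, expected to fall between 3000 nM and 30000 nM.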

Compound 4, half-maximal inhibitory concentration: > 50000 nM
Compound 4: no number, only a limit; the forecaster's own chance of this, stated with the estimate: 10%; at least 5.5-fold (0.74 log units) between middle value and limit.
By their numbers in this assay, from the lowest: compounds 3, 1 and 2 (each within the scatter of the next). At a limit, above all of these: compound 4.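

In this assay compound 4 gives no number, only a limit of the assay: the limit of > 50000 nM in this assay, at which 1 of the 4 values shown sits.

Compounds 1, 2 and 3 stay within the scatter of one another, but the 1,3-dicarboxypropyl group on the amide-type nitrogen produces steps beyond the scatter: an at least 7.3-fold higher number from compound 3 to compound 4 (0.86 log units; beyond the scatter), an at least 4.1-fold higher number from compound 2 to compound 4 (0.61 log units; beyond the scatter) and an at least 5.2-fold higher number from compound 1 to compound 4 (0.72 log units; beyond the scatter). Within the data shown here, the number at this position is therefore not indifferent to every group placed there, as the earlier compounds alone might have suggested.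

The compounds shown do not tell whether a chain with a single carboxylic acid would give a step of this kind, or whether a methyl ester or an amine in its place would stay with compounds 1, 2 and 3. They also leave open how far the true value of compound 4 lies past its limit.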